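Swapping Hydroxy for Amino on a Weak Enzyme Inhibitor

This account rests on a few compounds, and the source may have more. Where it says the series, first, only, none or still open, it means among the compounds named here.

Of the compounds shown here, two have so far been measured in an assay on cells for inhibition of Indoleamine 2,3-dioxygenase 1 (Homo sapiens), read by HPLC, with a stated time of 20 min; on this read-out higher numbers stand for weaker inhibition and lower numbers for stronger inhibition. Compound 1 `Cn1cncc1-c1cc(Cl)ccc1N` gives 1200000 nM, and compound 2 `Oc1ccccc1-n1ccnc1` gives 16000 nM. Compound 2 therefore stands lowest of the two numbers, with compound 1 far higher; since these two differ in several places at once, the gap between them cannot be tied to any single change. Compound 3 `Nc1ccccc1-n1ccnc1` has not yet been measured. It differs from compound 2 in one place only: amino in place of hydroxy on an aromatic carbon. Within the data shown here, no single-point step between measured compounds exists to guide this change, so the expectation rests on the weak showing of the amino-bearing compound 1 in this assay. A modest weakening is expected, and compound 3 is estimated at 60000 nM, with a range from 15000 nM to 300000 nM. This means an expected step from compound 2 to compound 3 of a 3.8-fold higher number from compound 2 to compound 3 (0.57 log units; beyond the scatter).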

Compound 3, half-maximal inhibitory concentration: 1300000 nM
Compound 3: middle estimate off by 22-fold (1.34 log units), on the low side, outside the stated range (above it).
By their numbers in this assay, from the lowest: compound 2; then compounds 1 and 3 (each within the scatter of the next).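

Putting amino in place of hydroxy on this aromatic carbon gives an 81-fold higher number from compound 2 to compound 3 (1.91 log units; beyond the scatter) in this assay and shows that the read-out is highly sensitive to which of these two groups sits at this position. The change is large even though the two groups match in the counts available here: each has one heavy atom, one hydrogen-bond donor and one hydrogen-bond acceptor, and neither carries a net charge. No measurement available here accounts for the size of this step.

Going by these compounds, whether a methoxy group or a fluorine at the same place would stay close to compound 2 or fall away as amino does remains open. Also open, on these data alone, is whether swapping hydroxy for amino would have a similar effect on a different core.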